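Bromo for trifluoromethyl on compound 3

The source may report more compounds than this note shows. Statements on the series, on what has been measured and on what is new or still open speak of the compounds shown alone.

In a functional assay on HepG2 cells (Homo sapiens) for inhibition, read by MTT assay, with a stated time of 72 h (a lower number here means a stronger inhibitor, a higher number a weaker inhibitor), compound 1 `Cc1ccc(NC(=O)C2CCN(C/C=C/c3ccccc3)CC2)cc1` gives 33900 nM while compound 2 `COc1ccccc1NC(=O)C1CCN(C/C=C/c2ccccc2)CC1` gives 91200 nM and compound 3 `O=C(Nc1cccc(C(F)(F)F)c1)C1CCN(C/C=C/c2ccccc2)CC1` gives 11400 nM as the lowest number of the three. That makes compound 3 the strongest inhibitor measured so far, clearly ahead of both others. Compound 4 `O=C(Nc1cccc(Br)c1)C1CCN(C/C=C/c2ccccc2)CC1` has not yet been measured. It carries bromo in place of trifluoromethyl on an aromatic carbon and is otherwise identical to compound 3. Among the compounds with values here, only one measured step offers any guide: swapping one substituted phenyl group for another gave a 2.7-fold higher number from compound 1 to compound 2 (0.43 log units; beyond the scatter) as a modest change. That guide is loose, since it involves neither bromo nor trifluoromethyl. A small change is therefore expected in this assay with a slight rise at most likely, possibly nothing beyond the scatter. The expected result is a 1.3-fold higher number from compound 3 to compound 4 (0.12 log units; within the scatter) and no large shift is anticipated. In this assay the estimate for compound 4 is 15000 nM with an expected range from 6000 nM to 38000 nM around it.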

Compound 4, half-maximal inhibitory concentration: 19200 nM
Estimate against measurement, compound 4: 1.3-fold (0.11 log units) below, within the range that was stated.
By their numbers in this assay, from the lowest: compounds 3, 4 and 1 (each within the scatter of the next, the first and the last beyond it); then compound 2.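

In this assay, putting a single bromine atom in place of the four heavy atoms of trifluoromethyl, on an aromatic carbon, gives a 1.7-fold higher number from compound 3 to compound 4 (0.23 log units; within the scatter), so this swap at this position cannot be told apart from repeat-measurement variation. With the 3-bromophenyl group on the amide nitrogen, replacing 2-methoxyphenyl gives a 4.8-fold lower number from compound 2 to compound 4 (0.68 log units; beyond the scatter), whereas replacing 4-methylphenyl gives only a 1.8-fold lower number from compound 1 to compound 4 (0.25 log units; within the scatter), so among these three amides only the step from 2-methoxyphenyl clears the scatter. No measurement at hand bears on why the numbers fall this way.

As far as these compounds go, how an amine, a carboxylic acid or a nitrile would behave in place of bromo or trifluoromethyl remains open. So does the effect of a longer chain there, which could show whether this position tolerates more than these two groups.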